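Stilbene hydrazides against glioblastoma cells: dropping the chloro

The compounds below may be only part of what the source reports. "The series", "measured", "known", "first", "only" and "open" are said of these compounds alone.

Measured compounds:
compound 1 `COc1ccc(OC)c(/C=C/c2nnc(Nc3ccc(Cl)cc3)o2)c1`: 13800 nM
compound 2 `COc1ccc(OC)c(/C=C/C(=O)N/N=C/c2ccc(Cl)cc2)c1`: 340 nM

In a functional assay on SNB-19 cells (Homo sapiens) for antiproliferative activity, read by sulforhodamine B assay, with a stated time of 48 h (on this read-out lower numbers stand for stronger inhibition of growth and higher numbers for weaker inhibition of growth), compound 2 gives 340 nM, the lowest of the two numbers; compound 1 gives 13800 nM, a higher number that lies beyond the scatter. Compound 3 `COc1ccc(OC)c(/C=C/C(=O)N/N=C/c2ccccc2)c1` has not yet been measured. It differs from compound 2 by hydrogen in place of chloro on an aromatic carbon. For the measured compounds named here, no measured pair shows this change, so its effect is unknown here. Compound 3 is expected to lose a little against compound 2, a step of a 1.9-fold higher number from compound 2 to compound 3 (0.28 log units; within the scatter) that is expected to be small, near the scatter, toward weaker inhibition. The estimate for compound 3 is 650 nM, within 200 nM to 2200 nM.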

Compound 3, concentration for 50% growth inhibition: 4120 nM
The estimate for compound 3 lay 6.3-fold (0.80 log units) below the measured number, outside the stated range (above it).
By their numbers in this assay, from the lowest: compound 2; then compound 3; then compound 1.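

In this assay the change from 4-chlorophenyl to phenyl gives a 12-fold higher number from compound 2 to compound 3 (1.08 log units; beyond the scatter), so a single chlorine on this aromatic carbon, para to a large group, weighs heavily in the number. For the compounds shown here, this is the first comparison here that isolates one place, since compound 1 and compound 2 differ in more than one. Nothing measured here explains why the chloro matters so much. The compounds shown leave open whether fluoro, bromo, methyl or methoxy on this carbon would keep the growth inhibition of compound 2. They also leave open whether chloro would do the same on another carbon of this ring.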